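The source may report more compounds than this note shows. Statements on the series, on what has been measured and on what is new or still open speak of the compounds shown alone.

Measured compounds:
compound 1 `COC(=O)C1=C(C)NC(=O)N(C(=O)NCCCN2CCN(c3ccccc3O)CC2)C1c1ccc(F)c(F)c1` — 0.6 nM
compound 2 `CCOc1ccccc1N1CCN(CCCNC(=O)N2C(=O)NC(C)=C(C(=O)OC)C2c2ccc(F)c(F)c2)CC1` — 0.1 nM

In an assay on liver for binding affinity to Alpha-1A adrenergic receptor (Homo sapiens), using microsomes (on this read-out higher numbers stand for weaker inhibition and lower numbers for stronger inhibition), compound 2 gives the lowest of the two numbers; its nearest neighbour is compound 1, which in this assay gives 0.6 nM. Among the measured compounds shown here, the one measured step, a 6.0-fold lower number from compound 1 to compound 2 (0.78 log units; beyond the scatter), turns on the group on the oxygen of the phenyl ring at the far end of the chain.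

Compound 3 `COC(=O)C1=C(C)NC(=O)N(C(=O)NCCCN2CCN(c3cccc(Cl)c3)CC2)C1c1ccc(F)c(F)c1` has not yet been measured in this assay. It differs from compound 2 by 3-chlorophenyl in place of 2-ethoxyphenyl on an amine nitrogen in a ring. The step from compound 1 to compound 2 bears on this change only in part: it shows that the ethyl on the oxygen is worth a modest gain, and compound 3 gives that group up entirely while bringing in a chlorine at a different place on the ring. For the measured compounds named here, no measured step covers the chlorine itself. Compound 3 is therefore expected to lose part of the advantage of compound 2, by a step of about a 15-fold higher number from compound 2 to compound 3 (1.18 log units; beyond the scatter), with wide uncertainty. The estimate for compound 3 in this assay is 1.5 nM, ranging from 0.3 nM to 8 nM.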

Compound 3, inhibition constant: 0.7 nM
For compound 3 the middle estimate is 2.1-fold (0.33 log units) above the measured one; low and high end bracket the measured number.
By their numbers in this assay, from the lowest: compound 2; then compounds 1 and 3 (each within the scatter of the next).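

In this assay the 3-chlorophenyl group on the amine nitrogen in the ring does not keep the gain carried by 2-ethoxyphenyl, giving a 7.0-fold higher number from compound 2 to compound 3 (0.85 log units; beyond the scatter). Set against 2-hydroxyphenyl, the same group gives a 1.2-fold higher number from compound 1 to compound 3 (0.07 log units; within the scatter), so the two cannot be told apart here although they share neither the chlorine nor the oxygen, and among these three groups only 2-ethoxyphenyl stands apart. Nothing available explains either step.

The compounds shown leave open whether a methoxy or a propoxy group in place of the ethoxy would keep the gain seen with compound 2. They also leave open whether the chlorine of compound 3 matters at all, which a bromine or a methyl in its place, or an unsubstituted phenyl, would help to show.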